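Swapping the carbamoyl for fluoro on the core

This account rests on a few compounds, and the source may have more. Where it says the series, first, only, none or still open, it means among the compounds named here.

Compound 1 `C[C@H](Oc1cc2cc(C(N)=O)ccc2nc1N)c1cc(F)c(F)cc1-n1cccn1` is measured in an ADME assay on cells (Hepatocyte, Homo sapiens) for metabolic stability (a lower number here means slower removal, a higher number faster removal of the compound), where compound 1 gives 14 uL/min. Going by the values given here, compound 2 `C[C@H](Oc1cc2cc(C(N)=O)ccc2nc1N)c1cc(F)ccc1-n1cccn1` gives 13 uL/min in this assay, and the only measured one-place step is a 1.1-fold lower number from compound 1 to compound 2 (0.03 log units; within the scatter). Compound 3 `C[C@H](Oc1cc2cc(F)cc(F)c2nc1N)c1cc(C(=O)O)ccc1-n1cccn1` reaches only a limit of this assay, < 3 uL/min. Compound 1 and compound 2 thus sit within the scatter of each other, and the third value is a limit rather than a number.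

Compound 4 `C[C@H](Oc1cc2cc(F)ccc2nc1N)c1cc(F)c(F)cc1-n1cccn1` differs from compound 1 by fluoro in place of carbamoyl on an aromatic carbon. Among the compounds with values here, no measured step touches this position; compound 3 also lacks the carbamoyl but differs from compound 1 in several places, so its value offers no direct guide. The estimate means a step of a 1.8-fold higher number from compound 1 to compound 4 (0.25 log units; within the scatter). Compound 4 is expected to give 25 uL/min, estimated between 10 uL/min and 60 uL/min.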

Compound 4, intrinsic clearance in a liver preparation (reported as CLH), per the amount of preparation that the assay uses: 57 uL/min
For compound 4 the middle estimate is 2.3-fold (0.36 log units) below the measured one, within the range that was stated.
By their numbers in this assay, from the lowest: compounds 2 and 1 (each within the scatter of the next); then compound 4. At a limit, below all of these: compound 3.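

This position on the core does affect removal: replacing carbamoyl with fluoro on this aromatic carbon gives a 4.1-fold higher number from compound 1 to compound 4 (0.61 log units; beyond the scatter) in this assay. Going by these compounds alone, the only earlier one-place step, a 1.1-fold lower number from compound 1 to compound 2 (0.03 log units; within the scatter), involved a different aromatic carbon and showed no such separation. Nothing measured here bears on why this change gives faster removal. From the compounds shown here alone, it remains open whether the difference follows from losing the carbamoyl or from gaining the fluoro, and how a plain hydrogen, a nitrile or a methyl ester at this place would compare.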